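The source may hold more compounds than are shown below. What is called first, only, known or untested is meant among the compounds shown, and "the series" means these compounds.

In an assay on cells for agonist activity at ecdysone receptor (Bombyx mori), read by a luciferase reporter, with a stated time of 24 h (a lower number here means that less compound is needed, a higher number that more compound is needed for the effect), three compounds have been measured so far:

Compound 1, `CC(C)(C)N(NC(=O)c1ccccc1Br)C(=O)c1ccccc1Cl`, gives 316 nM.
Compound 2, `CC(C)(C)N(NC(=O)c1cccc(Cl)c1)C(=O)c1ccccc1Cl`, gives 155 nM.
Compound 3, `CC(C)(C)N(NC(=O)c1cccc(C#N)c1)C(=O)c1ccccc1Cl`, gives 955 nM.

Compound 3 gives the highest of the three numbers in this assay: the step of a 3.0-fold higher number from compound 1 to compound 3 (0.48 log units; beyond the scatter) and the step of a 6.2-fold higher number from compound 2 to compound 3 (0.79 log units; beyond the scatter) both run upward and both lie beyond the scatter. Compound 4, `COc1cccc(C(=O)NN(C(=O)c2ccccc2Cl)C(C)(C)C)c1`, differs from compound 3 in one place: methoxy in place of cyano on an aromatic carbon.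

Among the measured compounds shown here, only one of the measured steps touches the same aromatic carbon, namely a 6.2-fold higher number from compound 2 to compound 3 (0.79 log units; beyond the scatter), which shows that exchanging the group at this position shifted the number well beyond the scatter. The other steps, a 2.0-fold lower number from compound 1 to compound 2 (0.31 log units; beyond the scatter) and a 3.0-fold higher number from compound 1 to compound 3 (0.48 log units; beyond the scatter), change the ring position as well as the group, so they bear on the change only loosely. For the measured compounds named here, no measured compound carries a methoxy group, so the direction for compound 4 rests on the observation that the cyano-bearing compound 3 sits at the top of the range while compound 2 sits at the bottom.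

Compound 4 is therefore expected to give a number somewhat lower than compound 3, a step of about a 2.1-fold lower number from compound 3 to compound 4 (0.33 log units; beyond the scatter) in this assay. The estimate for compound 4 is 450 nM, with a range from 150 nM to 1300 nM.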

Compound 4, half-maximal effective concentration: 52.5 nM
Beside the measured number, compound 4's estimate is 8.6-fold (0.93 log units) above it; the whole stated range lies above it.
By their numbers in this assay, from the lowest: compound 4; then compound 2; then compound 1; then compound 3.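

In this assay, the exchange of cyano for methoxy on this aromatic carbon gives an 18-fold lower number from compound 3 to compound 4 (1.26 log units; beyond the scatter), a large step that goes further than the modest 6.2-fold higher number from compound 2 to compound 3 (0.79 log units; beyond the scatter) and shows that this position can respond strongly to a change between two groups of equal heavy-atom count. Methoxy also goes past the best group seen so far at this carbon, with a 3.0-fold lower number from compound 2 to compound 4 (0.47 log units; beyond the scatter), so chloro no longer marks the low end and the three groups at this carbon now run methoxy, chloro, cyano from the lowest number to the highest, while the exchange of 2-bromophenyl for 3-methoxyphenyl gives a 6.0-fold lower number from compound 1 to compound 4 (0.78 log units; beyond the scatter). No measurement at hand accounts for this order.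

The compounds shown leave open whether a longer chain such as ethoxy, or a hydroxyl or an amine on the same aromatic carbon, would bring the number lower still or raise it again. They also leave open whether methoxy would keep its place in this order if another part of the shared core were changed.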